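A few compounds are considered here, and "the series" means these few. Any claim that something is new, unique, unknown or untested is made for them only; others in the source may bear on it.

Measured so far:
- compound 1, `N#CC1=C(N)N(c2ccc(S(N)(=O)=O)cc2)C2=C(CCCC2)C1c1ccc(O)cc1`: 100%
- compound 2, `COc1ccc(C2C(C#N)=C(N)N(c3ccc(S(N)(=O)=O)cc3)C3=C2CCCC3)cc1`: 100%
- compound 3, `N#CC1=C(N)N(c2ccc(S(N)(=O)=O)cc2)C2=C(CCCC2)C1c1cccc([N+](=O)[O-])c1`: 12%

In a functional assay on Ehrlich cells (Mus musculus) for cytotoxicity, read by trypan blue exclusion, with a stated time of 2 h, tested at 100 ug/mL (on this read-out higher numbers stand for a stronger effect at the one concentration tested and lower numbers for a weaker effect), compound 1 gives 100% and compound 2 gives 100%; the step of no change at the digits printed from compound 1 to compound 2 (within the scatter) shows that methyl in place of hydrogen on the oxygen made no difference. Compound 3 stands lowest of the three, with 12% in this assay. The steps of a number 88 percentage points lower from compound 1 to compound 3 (beyond the scatter) and a number 88 percentage points lower from compound 2 to compound 3 (beyond the scatter) are both large drops, so the 3-nitrophenyl group goes with a much weaker effect than the 4-hydroxyphenyl or 4-methoxyphenyl group on the saturated ring carbon.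

Compound 4, `N#CC1=C(N)N(c2ccc(S(N)(=O)=O)cc2)C2=C(CCCC2)C1c1ccc([N+](=O)[O-])cc1`, differs from compound 3 only as follows: 4-nitrophenyl in place of 3-nitrophenyl on a saturated ring carbon. Among the measured compounds shown here, no measured step covers a move of the nitro group around its ring, so there is no direct guide to the size or direction of the change in this assay. For the measured compounds named here, the two measured steps show only that the 3-nitrophenyl compound sits far below the two others. The step of a number 23 percentage points higher from compound 3 to compound 4 (beyond the scatter) is therefore an uncertain estimate, and compound 4 is expected to give about 35% in this assay, within 5% to 90%.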

Compound 4, a percentage reported as activity, at one concentration (the size of the read-out at that concentration, not a potency): 20%
Beside the measured number, compound 4's estimate is 15 percentage points above it, within the range that was stated.
By their numbers in this assay, from the lowest: compounds 3 and 4 (each within the scatter of the next); then compounds 1 and 2 (each within the scatter of the next).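

In this assay, 4-nitrophenyl in place of 3-nitrophenyl on the saturated ring carbon gives a number 8 percentage points higher from compound 3 to compound 4 (within the scatter), so moving the nitro group around its ring makes no readable difference here. The weak effect therefore goes with both nitrophenyl groups, not just one of them: nitro in place of methoxy gives a number 80 percentage points lower from compound 2 to compound 4 (beyond the scatter), and nitro in place of hydroxy gives a number 80 percentage points lower from compound 1 to compound 4 (beyond the scatter), both large drops like those already seen with 3-nitrophenyl. No measurement available here explains why the nitro compounds read so much lower.

As far as these compounds go, it remains open whether an amine or a carboxylic acid in place of the nitro group would read like the hydroxy and methoxy compounds or like the nitro ones. A 3-methoxyphenyl group would also show whether the methoxy result holds when that group is moved around the ring.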